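This account rests on a few compounds, and the source may have more. Where it says the series, first, only, none or still open, it means among the compounds named here.

Compound 3 `C=CCn1c(=O)/c(=C\c2ccccc2Cl)[nH]c(=O)/c1=C\c1ccccc1OC` gives the lowest of the two numbers reported in a functional assay on Huh-7 cells (Homo sapiens) for cytotoxicity, read by CCK-8 assay, with a stated time of 72 h (on this read-out lower numbers stand for stronger inhibition and higher numbers for weaker inhibition), at 6400 nM, with compound 1 `C=CCn1c(=O)/c(=C\c2cccc(Cl)c2)[nH]c(=O)/c1=C\c1ccccc1OC` nearest at 8900 nM; compound 2 `COc1ccccc1/C=c1/[nH]c(=O)/c(=C\c2cccc(Cl)c2Cl)[nH]c1=O` is recorded in this assay as "not active" (no number reported). Compound 4 `C=CCn1c(=O)/c(=C\c2cccc(Cl)c2Cl)[nH]c(=O)/c1=C\c1ccccc1OC` carries chloro in place of hydrogen on an aromatic carbon, ortho to a chloro group. Going by the values given here, the only measured step, a 1.4-fold lower number from compound 1 to compound 3 (0.14 log units; within the scatter), merely moves the chlorine and stays within the scatter. Compound 2 bears the same 2,3-dichlorophenyl as compound 4 and is not active, although it also lacks the allyl group. A loss is therefore expected, though an uncertain one, and the step of a 1.9-fold higher number from compound 3 to compound 4 (0.27 log units; within the scatter) is the estimate. Compound 4 is expected to give about 12000 nM, between 4000 nM and 40000 nM.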

Compound 4, half-maximal inhibitory concentration: 1200 nM
Compound 4: the middle estimate sits 10-fold (1.00 log units) above what was measured; measured number outside the range, below it.
By their numbers in this assay, from the lowest: compound 4; then compounds 3 and 1 (each within the scatter of the next).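

Chloro in place of hydrogen, ortho to a chloro group, gives a 5.3-fold lower number from compound 3 to compound 4 (0.73 log units; beyond the scatter) in this assay, and the same 2,3-dichlorophenyl gives a 7.4-fold lower number from compound 1 to compound 4 (0.87 log units; beyond the scatter); both steps lie beyond the scatter, whereas moving the single chlorine did not. The 2,3-dichlorophenyl is thus compatible with a measurable number when the allyl group is present, although compound 2, which lacks that group, is recorded as not active. Nothing available here explains the gain.

As far as these compounds go, whether bromo, methyl or methoxy at this position would behave like chloro remains open, as does the effect of a longer chain in place of the allyl group.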